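Swapping Methoxy Positions on the Anilino Ring

The source may hold more compounds than are shown below. What is called first, only, known or untested is meant among the compounds shown, and "the series" means these compounds.

Measured compounds, each tested in a functional assay on PC-3 cells (Homo sapiens) for cytotoxicity, read by MTT assay, with a stated time of 72 h; on this read-out higher numbers stand for weaker inhibition and lower numbers for stronger inhibition:
- compound 1 (`FC(F)(F)c1ccc(CSc2nc(Nc3cccc(Br)c3)c3ccccc3n2)cc1`) gives 8680 nM
- compound 2 (`COc1ccc(Nc2nc(SCc3ccc(C(F)(F)F)cc3)nc3ccccc23)c(OC)c1`) gives 32500 nM

For the measured compounds named here, compound 2 stands at the higher of the two numbers, which in this assay means weaker inhibition; its only neighbour is compound 1, and the step of a 3.7-fold higher number from compound 1 to compound 2 (0.57 log units; beyond the scatter) lies beyond the usual scatter. That step swapped the whole ring attached to the nitrogen on the shared core: 2,4-dimethoxyphenyl in place of 3-bromophenyl.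

Compound 3 (`COc1cc(Nc2nc(SCc3ccc(C(F)(F)F)cc3)nc3ccccc23)cc(OC)c1`) is not yet measured. It differs from compound 2 only in the arrangement of the same atoms: 3,5-dimethoxyphenyl in place of 2,4-dimethoxyphenyl on a nitrogen on an aromatic ring. Going by the values given here, no measured pair shows what moving the two methoxy groups around the ring does; the step from compound 1 to compound 2 changed both the halogen and the methoxy pattern at once, so it does not speak to this change on its own.

With nothing to anchor a direction, compound 3 is expected to stay close to compound 2, the estimated step of a 1.3-fold lower number from compound 2 to compound 3 (0.11 log units; within the scatter) being no more than scatter in this assay, with a wide range to allow for either direction. The expected value for compound 3 is therefore 25000 nM, between 7000 nM and 90000 nM.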

Compound 3, half-maximal inhibitory concentration: > 50000 nM
Compound 3 gave a limit, no number; the forecaster's own chance of this, stated with the estimate: 15%; middle value at least 2.0-fold (0.30 log units) from the limit.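

In this assay, compound 3 gives > 50000 nM, which is a limit of the assay and not a number. Rearranging the two methoxy groups, with the atoms of the ring left unchanged, isolates this change for the first time, and the result is an at least 1.5-fold higher number from compound 2 to compound 3 (0.18 log units; that floor lies within the scatter); this floor lies within the usual scatter, so the pair shows no gain from the 3,5-dimethoxyphenyl arrangement, but it does not establish a real loss either. The comparison with the bromine-bearing ring is firmer, at an at least 5.7-fold higher number from compound 1 to compound 3 (0.76 log units; beyond the scatter), so 3,5-dimethoxyphenyl, like 2,4-dimethoxyphenyl, gives weaker inhibition at this place on the nitrogen than 3-bromophenyl does.

The true value of compound 3 remains unknown, so these compounds leave open whether the arrangement of the methoxy groups matters at all or only appears not to. They also leave open whether the weaker inhibition follows from having two methoxy groups or from losing the bromine, a question that a ring carrying one methoxy group, a chlorine or an amine could help to answer.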